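Notes on the heteroaryl exchange from compound 3 to compound 4

This account rests on a few compounds, and the source may have more. Where it says the series, first, only, none or still open, it means among the compounds named here.

The shared core is carried by compound 1 `O=C(COc1ccccc1)Nc1cccc(-c2nc3ncccc3o2)c1`, which in an assay on brain for inhibition of Fatty-acid amide hydrolase 1 (Rattus norvegicus) (on this read-out lower numbers stand for stronger inhibition and higher numbers for weaker inhibition), gives 18000 nM. Compound 2 `CC(C)c1ccc(OCC(=O)Nc2cccc(-c3nc4ncccc4o3)c2)cc1` gives 2100 nM in this assay, and compound 3 `O=C(COc1ccc(C2CCCCC2)cc1)Nc1cccc(-c2nc3ncccc3o2)c1` gives 2600 nM. Compound 3 stands second highest of the three numbers: the step of a 6.9-fold lower number from compound 1 to compound 3 (0.84 log units; beyond the scatter) lies beyond the scatter, while the step of a 1.2-fold higher number from compound 2 to compound 3 (0.09 log units; within the scatter) lies within it, so compound 2 and compound 3 cannot be told apart. Compound 4 `O=C(COc1ccc(C2CCCCC2)cc1)Nc1cccc(-c2nc3ncccc3[nH]2)c1` is not yet measured. It differs from compound 3 by a group of 9 heavy atoms (6 carbon, 3 nitrogen; one five-membered aromatic ring with 2 hetero atoms, one six-membered aromatic ring with 1 hetero atom) in place of a group of 9 heavy atoms (6 carbon, 2 nitrogen, 1 oxygen; one five-membered aromatic ring with 2 hetero atoms, one six-membered aromatic ring with 1 hetero atom), on an aromatic carbon. Among the compounds with values here, none of the measured steps touches this part of the molecule: the steps of an 8.6-fold lower number from compound 1 to compound 2 (0.93 log units; beyond the scatter) and a 6.9-fold lower number from compound 1 to compound 3 (0.84 log units; beyond the scatter) concern the aromatic carbon carrying isopropyl or cyclohexyl, not the group now exchanged. Within the data shown here, no step beyond the scatter is therefore expected, and the expected step of a 1.2-fold higher number from compound 3 to compound 4 (0.06 log units; within the scatter) rests on no measured precedent. Compound 4 is expected to give 3000 nM in this assay, with a range from 800 nM to 12000 nM.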

Compound 4, half-maximal inhibitory concentration: 47000 nM
Compound 4: the middle estimate sits 16-fold (1.19 log units) below what was measured; measured number outside the range, above it.
By their numbers in this assay, from the lowest: compounds 2 and 3 (each within the scatter of the next); then compound 1; then compound 4.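

The heteroaryl group on this aromatic carbon, meta to a large group, is not a silent part of the molecule: in this assay the exchange gives an 18-fold higher number from compound 3 to compound 4 (1.26 log units; beyond the scatter) and is the only listed step at this position. The two groups match in heavy-atom count and ring types, so the step goes with one oxygen exchanged for one nitrogen, with 1 hydrogen-bond donor and 2 hydrogen-bond acceptors entering where 0 and 3 leave. Nothing available accounts for the size of this step.

Open, on these data alone, is whether the step follows the hydrogen on the new ring nitrogen or the loss of the oxygen, which a methyl on that nitrogen or a sulfur in place of that oxygen would help to separate. Also open, as far as these compounds go, is whether the exchange carries the same weight with isopropyl in place of cyclohexyl.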